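The source may report more compounds than this note shows. Statements on the series, on what has been measured and on what is new or still open speak of the compounds shown alone.

Compound 1 `CCCSc1nc(N/N=C/c2ccccc2Cl)c2nnn(Cc3ccccc3)c2n1` gives 13800 nM in a functional assay on MCF7 cells (Homo sapiens) for antiproliferative activity, read by MTT assay, with a stated time of 72 h; on this read-out higher numbers stand for weaker inhibition and lower numbers for stronger inhibition. Compound 2 `CCCSc1nc(N/N=C/c2cccc(Cl)c2)c2nnn(Cc3ccccc3)c2n1` gives only a limit in this assay, > 64000 nM. Compound 3 `CCCSc1nc(N/N=C/c2ccccc2)c2nnn(Cc3ccccc3)c2n1` likewise gives only a limit, > 64000 nM.

Compound 3 thus stands at the limit, where compound 2 also sits (the limit of > 64000 nM in this assay, at which 2 of the 3 values shown sit); no number is read for it. Compound 4 `CCCSc1nc(N/N=C/c2ccc3ccccc3c2)c2nnn(Cc3ccccc3)c2n1` differs from compound 3 in one place: naphthalen-2-yl in place of phenyl on a carbon with a double bond to nitrogen. Among the measured compounds shown here, no measured step alters the ring in this way. The steps that exist concern the chloro group: an at least 4.6-fold higher number from compound 1 to compound 3 (0.66 log units; beyond the scatter) and an at least 4.6-fold higher number from compound 1 to compound 2 (0.66 log units; beyond the scatter), both toward weaker inhibition, and a step that the two limits leave unreadable from compound 2 to compound 3. From the compounds shown here alone, compound 3 already sits at the limit; any further weakening could not be read, and a second aromatic ring is untested. Compound 4 is expected to move by an at least 1.8-fold lower number from compound 3 to compound 4 (0.26 log units; that floor lies within the scatter), a small gain at most, with a fair chance of another limit. Compound 4 is estimated at 35000 nM, range 8000 nM to 150000 nM.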

Compound 4, half-maximal inhibitory concentration: > 64000 nM
Compound 4: a limit, no number; the forecaster's own chance of this, stated with the estimate: 50%; at least 1.8-fold (0.26 log units) between middle value and limit.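

In this assay naphthalen-2-yl on a carbon with a double bond to nitrogen gives no readable gain over phenyl or 3-chlorophenyl, and the steps among compound 2, compound 3 and compound 4 cannot be read, since all three values are limits. Naphthalen-2-yl in place of 2-chlorophenyl gives an at least 4.6-fold higher number from compound 1 to compound 4 (0.66 log units; beyond the scatter) and so does not recover the one measured number. A second aromatic ring leaves compound 4 at a limit as well: the limit of > 64000 nM in this assay, at which 3 of the 4 values shown sit.

Still open, from the compounds shown here alone, is whether an amine or a carboxylic acid on the phenyl would give a number at this position. Also open, going by these compounds, is how the 2-chlorophenyl value would respond to a longer chain on the sulfur.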